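Replacing cycloheptylmethyl on the carbonyl of compound 2

The compounds below may be only part of what the source reports. "The series", "measured", "known", "first", "only" and "open" are said of these compounds alone.

In a functional assay on Shh Light II cells (Mus musculus) for inhibition, read by a luciferase reporter (a higher number here means a weaker inhibitor, a lower number a stronger inhibitor), compound 1 `O=C(Nc1ccccc1Cl)N1CCN(c2nc(-c3ccc4ccccc4n3)no2)CC1` gives 140 nM, compound 2 `O=C(CC1CCCCCC1)N1CCC(c2nc(-c3ccc4ccccc4n3)no2)CC1` gives 840 nM and compound 3 `COc1ccccc1NC(=O)N1CCC(c2noc(-c3ccc4ccccc4n3)n2)CC1` gives 2400 nM. Compound 2 therefore stands in the middle of these three numbers, and its gaps to the other two lie beyond the scatter.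

Compound 4 `O=C(NC1CC[S+]([O-])CC1)N1CCC(c2nc(-c3ccc4ccccc4n3)no2)CC1` differs from compound 2 in one place: a group of 8 heavy atoms (5 carbon, 1 nitrogen, 1 oxygen, 1 sulfur; one six-membered non-aromatic ring with 1 hetero atom) in place of a group of 8 heavy atoms (8 carbon; one seven-membered non-aromatic ring of carbon only), on a carbonyl carbon. Going by the values given here, no measured step covers this change, so the expectation is only loosely supported. Compound 4 shares the amide hydrogen with compound 3, and compound 3 gives 2400 nM. Compound 1 also has it, however, and compound 1 gives 140 nM, which goes against reading that feature as a penalty. The cores of these compounds also differ.

A moderate move towards a weaker inhibitor in this assay, somewhat beyond the scatter, is expected, and the estimated step is a 2.4-fold higher number from compound 2 to compound 4 (0.38 log units; beyond the scatter). The estimate for compound 4 is 2000 nM, with an expected range of 500 nM to 8000 nM.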

Compound 4, half-maximal inhibitory concentration: 850 nM
Beside the measured number, compound 4's estimate is 2.4-fold (0.37 log units) above it, within the range that was stated.
By their numbers in this assay, from the lowest: compound 1; then compounds 2 and 4 (each within the scatter of the next); then compound 3.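

In this assay, the carbonyl carbon whose other neighbour is the amide-type nitrogen in a ring accepts this exchange with no readable consequence: the result is a 1.0-fold higher number from compound 2 to compound 4 (0.01 log units; within the scatter). Going by these compounds alone, this is the first one-place comparison at this position, and it shows that cycloheptylmethyl, with 0 hydrogen-bond donors and 0 hydrogen-bond acceptors, and the six-membered non-aromatic ring group, with 1 of each, cannot be told apart. Nothing measured here accounts for this outcome.

The exchange alters the ring, the hetero atoms and the amide hydrogen together, so their separate contributions remain unresolved. Also open, on these data alone, is whether this position stays as accommodating with a primary amine, a carboxylic acid or a longer alkyl chain on the carbonyl carbon.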